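Sulfonyl addition on the core nitrogen of compound 1

The compounds below may be only part of what the source reports. "The series", "measured", "known", "first", "only" and "open" are said of these compounds alone.

Compound 1 `COc1ccc(-c2cc(=O)c3c(OC)cc(OC)cc3[nH]2)cc1` is examined in an ADME assay on BJ cells (Homo sapiens) for antiproliferative activity, with a stated time of 72 h; a lower number here means that less compound is needed, a higher number that more compound is needed for the effect. In this assay compound 1 gives > 62000 nM, which is a limit of the assay rather than a number. Compound 2 `COc1ccc(-c2[nH]c3cc(OC)cc(OC)c3c(=O)c2I)cc1` carries iodo in place of hydrogen on an aromatic carbon. In this assay compound 2 gives > 86200 nM, again a limit. The step that the two limits leave unreadable from compound 1 to compound 2 therefore cannot be read. One value sits at the limit of > 62000 nM in this assay, at which 1 of the 2 values shown sits. The other sits at the limit of > 86200 nM in this assay, at which 1 of the 2 values shown sits. Compound 3 `COc1ccc(-c2cc(=O)c3c(OC)cc(OC)cc3n2S(=O)(=O)c2ccc(C=O)cc2)cc1` differs from compound 1 by (4-formylphenyl)sulfonyl in place of hydrogen on an aromatic nitrogen. Among the measured compounds shown here, no measured step bears directly on this change, and the single step available gives no direction or size. The step of an at least 1.2-fold lower number from compound 1 to compound 3 (0.09 log units; that floor lies within the scatter) is expected to remain within the scatter. Compound 3 is estimated at 50000 nM in this assay, between 15000 nM and 120000 nM, with a fair chance that only a limit is reported.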

Compound 3, half-maximal effective concentration: > 34400 nM
Compound 3: no number, only a limit; the forecaster's own chance of this, stated with the estimate: 70%; the middle value does not contradict the limit.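

In this assay compound 3 gives > 34400 nM, which is a limit. Compound 1 also has only a limit, so the step between compound 1 and compound 3 cannot be read. The compounds shown leave open whether (4-formylphenyl)sulfonyl in place of hydrogen on the aromatic nitrogen changes the concentration needed.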